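Isoflavone side-chain variation: from a carboxylic acid to a glycol ether

The compounds below may be only part of what the source reports. "The series", "measured", "known", "first", "only" and "open" are said of these compounds alone.

Measured compounds:
Compound 1, `O=C(O)CCCCCCCCCCCOc1ccc2c(=O)c(-c3ccc(O)cc3)coc2c1`: 130 nM
Compound 2, `O=c1c(-c2ccc(O)cc2)coc2cc(OCCCCCCCCCCCCO)ccc12`: 1700 nM
Compound 3, `O=C(O)CCCCCCCOc1ccc2c(=O)c(-c3ccc(O)cc3)coc2c1`: 40 nM

In an assay (Cricetulus griseus) for inhibition of aldehyde dehydrogenase, mitochondrial (Homo sapiens) (a higher number here means a weaker inhibitor, a lower number a stronger inhibitor), compound 3 gives the lowest of the three numbers. Its neighbours are reached by a 3.3-fold lower number from compound 1 to compound 3 (0.51 log units; beyond the scatter) and by a 43-fold lower number from compound 2 to compound 3 (1.63 log units; beyond the scatter), so compound 3 stands apart from both of the others, and most clearly from compound 2. The chain terminus matters in this set: a 13-fold higher number from compound 1 to compound 2 (1.12 log units; beyond the scatter), and that change is the exchange of the acid end for a hydroxyl.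

Compound 4, `O=c1c(-c2ccc(O)cc2)coc2cc(OCCOCCOCCO)ccc12`, has not yet been measured in this assay. It differs from compound 3 by 2-(2-hydroxyethoxy)ethoxy in place of 5-carboxypentyl on a saturated chain carbon, two bonds along the chain from an oxygen on an aromatic ring. The chain becomes shorter and ends in a hydroxyl rather than a carboxylic acid. Within the data shown here, no measured step covers exactly this exchange, but the loss of the acid end in the step from compound 1 to compound 2 was large, and the step from compound 2 to compound 3 was larger still. The expectation is therefore a higher number for compound 4, probably of comparable size: a 30-fold higher number from compound 3 to compound 4 (1.48 log units; beyond the scatter) is expected. Compound 4 is estimated at 1200 nM, within a range from 300 nM to 5000 nM.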

Compound 4, half-maximal inhibitory concentration: 40 nM
Compound 4: the middle estimate sits 30-fold (1.48 log units) above what was measured; measured number below the stated range.
By their numbers in this assay, from the lowest: compounds 3 and 4 (each within the scatter of the next); then compound 1; then compound 2.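

With 2-(2-hydroxyethoxy)ethoxy in place of 5-carboxypentyl, on a saturated chain carbon two bonds along the chain from an oxygen on an aromatic ring, the result is no change at the digits printed from compound 3 to compound 4 (within the scatter) in this assay, so a carboxylic acid at the chain end is not needed for a number this low. Compound 4 therefore goes against the link between the acid end and the lower number suggested by a 13-fold higher number from compound 1 to compound 2 (1.12 log units; beyond the scatter), and that link now rests on the all-carbon chains of compound 1 and compound 2 alone. Nothing available here accounts for the two chains reading alike in this assay, and this result cannot by itself separate the part played by the ether oxygens from that of the terminal hydroxyl.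

The compounds shown leave open how far the 2-(2-hydroxyethoxy)ethoxy chain can be varied, since they include no longer chain of repeating ether units and no version of it ending in a methoxy group, an amine or a carboxylic acid. They also leave open whether a chain with a single ether oxygen would read like compound 4 or like the all-carbon alcohol, compound 2.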